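The compounds below may be only part of what the source reports. "The series", "measured", "known", "first", "only" and "open" are said of these compounds alone.

In a functional assay on A549 cells (Homo sapiens), read by sulforhodamine B assay, with a stated time of 5 days (a lower number here means a stronger inhibitor of growth, a higher number a weaker inhibitor of growth), compound 1 `OC[C@H]1O[C@@H](n2cc(F)c3c(-c4ccccc4)ncnc32)[C@H](O)[C@@H]1O` gives > 10000 nM, which is a limit of the assay. Going by the values given here, compound 2 `OC[C@H]1O[C@@H](n2cc(F)c3c(-c4cccs4)ncnc32)[C@H](O)[C@@H]1O` gives 61 nM, the only true number so far. Among the compounds with values here, the single measured step, an at least 160-fold lower number from compound 1 to compound 2 (2.21 log units; beyond the scatter), is large and rests on one side on (the limit of > 10000 nM in this assay, at which 1 of the 2 values shown sits). Compound 3 `OC[C@H]1O[C@@H](n2cc(F)c3c(-c4ccoc4)ncnc32)[C@H](O)[C@@H]1O` carries furan-3-yl in place of thiophen-2-yl on an aromatic carbon. The five-membered aromatic ring of compound 2 at 61 nM is kept, so no return towards the large step is expected. The expected step, a 1.6-fold higher number from compound 2 to compound 3 (0.21 log units; within the scatter), stays within the scatter, if anything towards a higher number. Compound 3 is estimated at 100 nM, range 30 nM to 400 nM.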

Compound 3, concentration for 50% growth inhibition: 60 nM
For compound 3 the middle estimate is 1.7-fold (0.22 log units) above the measured one; low and high end bracket the measured number.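

In this assay, furan-3-yl in place of thiophen-2-yl on this aromatic carbon stays within the scatter (a 1.0-fold lower number from compound 2 to compound 3 (0.01 log units; within the scatter)), so the position accepts either sulfur or oxygen as the hetero atom of a five-membered aromatic ring. Furan-3-yl in place of phenyl repeats the large step (an at least 160-fold lower number from compound 1 to compound 3 (2.22 log units; beyond the scatter)), so that step no longer rests on thiophen-2-yl alone. Its full size cannot be read, since compound 1 stands at a limit: the limit of > 10000 nM in this assay, at which 1 of the 3 values shown sits.

Open, from the compounds shown here alone, is how a pyridine ring, a methyl group or an amine at this position would read. Also open, going by these compounds, is whether ring size alone separates compound 1 from compound 2 and compound 3.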